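A Second Pyrazole Variant on the Shared Core

A few compounds are considered here, and "the series" means these few. Any claim that something is new, unique, unknown or untested is made for them only; others in the source may bear on it.

Of the compounds shown here, three with a shared core have been measured in a functional assay on CHO cells for antagonist activity at sphingosine 1-phosphate receptor 2 (Homo sapiens), read by fluorescence and calcium flux, with a stated time of 3 min; a lower number here means a stronger inhibitor, a higher number a weaker inhibitor. Compound 1 `Cc1cc(NNC(=O)Nc2cc(Cl)nc(Cl)c2)ncc1N(C)C` gives 3600 nM there. Compound 2 `Cc1cc(NNC(=O)Nc2cc(Cl)nc(Cl)c2)ncc1C#N` gives 6000 nM in this assay, and compound 3 `Cc1cc(NNC(=O)Nc2cc(Cl)nc(Cl)c2)ncc1-c1ccn(C)n1` gives 4000 nM. Among these three numbers compound 3 stands second highest; its nearest neighbour is compound 1, which lies a 1.1-fold higher number from compound 1 to compound 3 (0.05 log units; within the scatter), and its furthest is compound 2, which lies a 1.5-fold lower number from compound 2 to compound 3 (0.18 log units; within the scatter). The remaining step, a 1.7-fold higher number from compound 1 to compound 2 (0.22 log units; within the scatter), is likewise within the scatter, so the three compounds cannot be placed in any order on the numbers shown.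

Compound 4 `Cc1cc(NNC(=O)Nc2cc(Cl)nc(Cl)c2)ncc1-c1cn(C)nc1C` differs from compound 3 in one place: 1,3-dimethyl-1H-pyrazol-4-yl in place of 1-methyl-1H-pyrazol-3-yl on an aromatic carbon. Going by the values given here, the steps that bear on this change are the two that alter the same aromatic carbon, the step from compound 1 to compound 3 and the step from compound 2 to compound 3, and both stayed inside the scatter. Since three quite different groups at this position gave numbers within the scatter of one another, the account expects no step beyond the scatter from compound 3 to compound 4 in this assay, that is no change at the digits printed from compound 3 to compound 4 (within the scatter). Compound 4 is accordingly estimated at 4000 nM in this assay, with a range from 1800 nM to 9000 nM.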

Compound 4, half-maximal inhibitory concentration: > 1400 nM
Compound 4: no number, only a limit; the forecaster's own chance of this, stated with the estimate: 10%; the middle value lies beyond the limit too.
By their numbers in this assay, from the lowest: compounds 1, 3 and 2 (each within the scatter of the next).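

Compound 4 gives only a limit in this assay, not a number, so the steps to it from compound 1, compound 2 and compound 3 cannot be read: the limit of > 1400 nM in this assay, at which 1 of the 4 values shown sits.

The compounds shown leave open whether 1,3-dimethyl-1H-pyrazol-4-yl on this aromatic carbon keeps compound 4 within the scatter of compound 1, compound 2 and compound 3, or takes it beyond that scatter.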